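Chain extension in a diamine series

A few compounds are considered here, and "the series" means these few. Any claim that something is new, unique, unknown or untested is made for them only; others in the source may bear on it.

Two measured compounds define the range. Compound 1 `CCCCCCCCCCCCNCCCN` gives 5.06 in a physicochemical assay for lipophilicity; a higher number here means a more lipophilic compound, a lower number a more polar compound; compound 2 `CCCCCCCCCCNCCN` gives 2.71 in this assay, the lower of the two numbers, and the gap between them lies beyond the scatter. Among the compounds with values here, compound 1 and compound 2 differ in more than one place, so no single step is counted between them.

Compound 3 `CCCCCCCCCCCCCCNCCN` is not yet measured. It differs from compound 2 by butyl in place of hydrogen on a saturated chain carbon, ten or more bonds along the chain from an amine nitrogen. Within the data shown here, no measured pair isolates this change, so the expectation rests on the two values alone, with compound 1 showing that a longer chain goes with a higher number. A rise well beyond the scatter is expected, estimated as a number 2.04 log units higher from compound 2 to compound 3 (beyond the scatter) in this assay. For compound 3 the estimate in this assay is 4.75, with a range from 3.9 to 5.6.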

Compound 3, partition coefficient: 4.5
Beside the measured number, compound 3's estimate is 0.25 log units above it, and the stated range covers the measured number.
By their numbers in this assay, from the lowest: compound 2; then compound 3; then compound 1.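

In this assay, butyl in place of hydrogen on a saturated chain carbon, ten or more bonds along the chain from an amine nitrogen, now gives a single-place step for the series: a number 1.79 log units higher from compound 2 to compound 3 (beyond the scatter). A second single-place step, 2-((2-aminoethyl)amino)ethyl in place of (3-aminopropyl)amino on a saturated chain carbon bound to a saturated chain carbon, gives a number 0.56 log units lower from compound 1 to compound 3 (beyond the scatter), so the number also moves beyond the scatter for a change other than the butyl addition, though by a modest step rather than a large one. No measurement here bears on the reason for either step.

On these data alone, a single butyl step cannot show whether the number follows chain length evenly, so a shorter ethyl group or a longer chain at this place remains open. As far as these compounds go, how a carboxylic acid on the chain would read in this assay also remains open.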